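Exchanging the aryl group on a triazole in a weak series

This account rests on a few compounds, and the source may have more. Where it says the series, first, only, none or still open, it means among the compounds named here.

Of the compounds shown here, two of one shared core have been measured. In an ADME assay on L02 cells (Homo sapiens) for antiproliferative activity, read by MTT assay, with a stated time of 48 h (on this read-out higher numbers stand for weaker inhibition and lower numbers for stronger inhibition), compound 1 `N#CC1=C(N)Oc2c(N)cc3nc4ccccc4nc3c2C12C(=O)N(Cc1cnnn1-c1ccccc1Br)c1ccccc12` gives 29200 nM. Compound 2 `COc1ccccc1-n1nncc1CN1C(=O)C2(C(C#N)=C(N)Oc3c(N)cc4nc5ccccc5nc4c32)c2ccccc21` reaches only a limit of this assay, > 50000 nM, so no number is known for it. Going by the values given here, the single measured step is an at least 1.7-fold higher number from compound 1 to compound 2 (0.23 log units; that floor lies within the scatter); its floor is set by the limit of > 50000 nM in this assay, at which 1 of the 2 values shown sits.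

Compound 3 `Cc1ccc(-n2nncc2CN2C(=O)C3(C(C#N)=C(N)Oc4c(N)cc5nc6ccccc6nc5c43)c3ccccc32)cc1C` differs from compound 2 by 3,4-dimethylphenyl in place of 2-methoxyphenyl on an aromatic nitrogen. Among the compounds with values here, no measured step touches the group on the aromatic nitrogen of the five-membered ring; the only step exchanges a group on an aromatic carbon and stays within the scatter. A step beyond the scatter in this assay is therefore not expected, and a limit remains likely. Compound 3 is expected at 45000 nM, with a range from 15000 nM to 120000 nM. This expectation means a step of an at least 1.1-fold lower number from compound 2 to compound 3 (0.04 log units; that floor lies within the scatter).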

Compound 3, half-maximal inhibitory concentration: > 50000 nM
Compound 3 gave a limit, no number (the forecaster's own chance of this, stated with the estimate: 50%); middle value at least 1.1-fold (0.04 log units) from the limit.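

In this assay compound 3 gives > 50000 nM, which is a limit and not a number. The group on the aromatic nitrogen of the five-membered ring now has a step of its own, with 3,4-dimethylphenyl in place of 2-bromophenyl: an at least 1.7-fold higher number from compound 1 to compound 3 (0.23 log units; that floor lies within the scatter). A second aryl group without the oxygen of 2-methoxyphenyl also ends at the limit, but the step between compound 2 and compound 3 cannot be read because neither has a number: the limit of > 50000 nM in this assay, at which 2 of the 3 values shown sit.

The compounds shown leave open how far compound 2 and compound 3 really lie beyond that limit. They also leave open whether a different group on the same nitrogen, such as an aminophenyl group or a longer chain ending in a carboxylic acid, would give a readable value in this assay.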